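Halogen swap at the pyridine ring of compound 3

A few compounds are considered here, and "the series" means these few. Any claim that something is new, unique, unknown or untested is made for them only; others in the source may bear on it.

Compound 3 `C[C@@H](Oc1cc2onc(CCC(=O)O)c2cc1Cl)c1ccc(F)cn1` sits, in an assay for inhibition of kynurenine 3-monooxygenase (Homo sapiens), read by mass spectrometry, with a stated time of 1 h (on this read-out higher numbers stand for weaker inhibition and lower numbers for stronger inhibition), at 3.16 nM. Compound 1 `Cc1ccc([C@@H](C)Oc2cc3onc(CCC(=O)O)c3cc2Cl)nc1` gives 3.16 nM in this assay, and compound 2 `O=C(O)CCn1c(=O)oc2cc(OCc3ccccn3)c(Cl)cc21` gives 3.16 nM, so compound 3 stands level with both within the scatter. Within the data shown here, the one step measured that touches the same position, from compound 1 to compound 3, reads no change at the digits printed from compound 1 to compound 3 (within the scatter), and it brought no change beyond the scatter. Compound 4 `C[C@@H](Oc1cc2onc(CCC(=O)O)c2cc1Cl)c1ccc(Cl)cn1` differs from compound 3 by chloro in place of fluoro on an aromatic carbon. Among the measured compounds shown here, no measured pair shows a chloro against a fluoro at this place, so the only guide is the step from compound 1 to compound 3, which was flat, and the general finding that all three measured compounds share the same value. Compound 4 is therefore expected to stay where compound 3 stands, with a step of a 1.0-fold higher number from compound 3 to compound 4 (0.01 log units; within the scatter), and its estimated value in this assay is 3.2 nM, expected to fall between 1.3 nM and 8 nM.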

Compound 4, half-maximal inhibitory concentration in the kynurenine 3-monooxygenase assay: 3.16 nM
Compound 4: the middle estimate sits 1.0-fold (0.01 log units) above what was measured, within the range that was stated.
By their numbers in the kynurenine 3-monooxygenase assay, from the lowest: compounds 1, 2, 3 and 4 (each within the scatter of the next).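

In the kynurenine 3-monooxygenase assay the swap from 5-fluoropyridin-2-yl to 5-chloropyridin-2-yl gives no change at the digits printed from compound 3 to compound 4 (within the scatter) and the swap of methyl for chloro gives no change at the digits printed from compound 1 to compound 4 (within the scatter), so methyl, fluoro and chloro on this aromatic carbon all stand level in this read-out. The earlier compounds shown here showed only that flatness, whereas a physicochemical assay for lipophilicity, read by HPLC, at pH 7.4 (on this read-out lower numbers stand for lower lipophilicity and higher numbers for higher lipophilicity), now separates this pair, with a number 0.44 log units higher from compound 3 to compound 4 (beyond the scatter) for the same swap. In the physicochemical assay compound 3 gives 2.47 and compound 4 gives 2.91. At this position, then, the change from fluoro to chloro leaves inhibition level while lipophilicity moves: the measured distribution coefficient of compound 3, 2.47, and of compound 4, 2.91, a number 0.44 log units higher (beyond the scatter).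

The compounds shown leave open whether a nitrile, an amine or a methoxy group at this place would also stand level in the kynurenine 3-monooxygenase assay. They also leave open how far a trifluoromethyl group there would move the distribution coefficient, and whether inhibition would then hold.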